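Nitro for Methyl on the Sulfonyl Ring of Compound 2

The source may report more compounds than this note shows. Statements on the series, on what has been measured and on what is new or still open speak of the compounds shown alone.

Measured so far:
compound 1 `CC(=O)c1ccc(NC(=O)C(CC(C)C)N(C(=O)c2ccccc2)S(=O)(=O)c2ccc(C)cc2)cc1` gives 54%
compound 2 `CC(=O)c1ccc(NC(=O)C2CC(O)CN2S(=O)(=O)c2ccc(C)cc2)cc1` gives 12.4%
compound 3 `CC(=O)c1ccc(NC(=O)C(CC(C)C)N(C(=O)c2ccccc2)S(=O)(=O)c2ccc([N+](=O)[O-])cc2)cc1` gives 45%

These readings come from a functional assay for inhibition, read by spectrophotometry, with a stated time of 20 min, tested at 1 mg/mL; on this read-out lower numbers stand for a weaker effect and higher numbers for a stronger effect at the one concentration tested. Compound 2 stands lowest of the three, and both compound 1 and compound 3 lie beyond the scatter above it. The difference between the core of compound 1 and the core of compound 2 is not broken down here.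

Compound 3 differs from compound 1 by one change, (nitro in place of methyl on an aromatic carbon), and the measured step was a number 9 percentage points lower from compound 1 to compound 3 (within the scatter). Compound 4 `CC(=O)c1ccc(NC(=O)C2CC(O)CN2S(=O)(=O)c2ccc([N+](=O)[O-])cc2)cc1` carries the same change on the core of compound 2, (nitro in place of methyl on an aromatic carbon).

Because a number 9 percentage points lower from compound 1 to compound 3 (within the scatter) stayed within the scatter, the expected step for compound 4 is likewise small, a number 2.4 percentage points lower from compound 2 to compound 4 (within the scatter). Compound 4 is therefore estimated at 10%, with a likely range from 0% to 28%.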

Compound 4, a percentage reported as inhibition, at one concentration (the size of the read-out at that concentration, not a potency): 43.2%
The estimate for compound 4 lay 33.2 percentage points below the measured number; the measured number lies above the stated range.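

Replacing methyl with nitro on the aromatic ring gave a number 30.8 percentage points higher from compound 2 to compound 4 (beyond the scatter) in this assay. Set beside the earlier step, the outcome of this change depends on the core that carries it: the same change on two cores in this assay, a number 9 percentage points lower (within the scatter) from compound 1 to compound 3 and a number 30.8 percentage points higher (beyond the scatter) from compound 2 to compound 4, 39.8 percentage points apart, beyond the scatter of two such steps

So, in this series, a step seen on one core cannot simply be carried over to the other, but two pairs do not show which part of the cores makes the difference, or why.

The compounds shown leave open how another group at the same place, such as an amine or a carboxylic acid, would behave on either core. They also leave open whether the rise on the core of compound 2 is particular to nitro.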